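Quinazoline series: varying the terminal amine on the propoxy chain

This account rests on a few compounds, and the source may have more. Where it says the series, first, only, none or still open, it means among the compounds named here.

Measured compounds:
compound 1 `COc1cc2c(Nc3ccc(C#N)cc3)ncnc2cc1OCCCN1CCCCC1` 18800 nM
compound 2 `COc1cc2c(Nc3ccc(C#N)cc3)ncnc2cc1OCCCN1CCC(C)CC1` 7900 nM

In a functional assay on SH-SY5Y cells (Homo sapiens) for antiproliferative activity, read by MTT assay, with a stated time of 72 h (a higher number here means a weaker inhibitor, a lower number a stronger inhibitor), compound 1 gives 18800 nM. Compound 2 gives 7900 nM in this assay, and the change of methyl in place of hydrogen on a saturated ring carbon produced a 2.4-fold lower number from compound 1 to compound 2 (0.38 log units; beyond the scatter). Compound 2 thus stands with the lowest number of the two measured compounds, and its step to compound 1 lies beyond the scatter.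

Compound 3 `COc1cc2c(Nc3ccc(C#N)cc3)ncnc2cc1OCCCN1CCN(c2ccncc2)CC1` is not yet measured. Its change from compound 2 is 4-(pyridin-4-yl)piperazin-1-yl in place of 4-methylpiperidin-1-yl on a saturated chain carbon, three bonds along the chain from an oxygen on an aromatic ring. Within the data shown here, no measured step concerns a replacement of the whole terminal ring; the single step from compound 1 to compound 2 concerns only a methyl added to that ring and was modest. The present change is much larger in what leaves and what enters, so the expected step carries considerable uncertainty. On balance a small step toward a lower number, of the order seen between compound 1 and compound 2, is expected: a 1.6-fold lower number from compound 2 to compound 3 (0.20 log units; within the scatter). For compound 3 the estimated value in this assay is 5000 nM, with a range from 1200 nM to 25000 nM.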

Compound 3, half-maximal inhibitory concentration: 31600 nM
Compound 3: middle estimate off by 6.3-fold (0.80 log units), on the low side; measured number outside the range, above it.
By their numbers in this assay, from the lowest: compound 2; then compounds 1 and 3 (each within the scatter of the next).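

At the terminal position on the propoxy chain, the earlier pair showed only what a methyl on the ring does, whereas here the whole ring is replaced: in this assay, 4-(pyridin-4-yl)piperazin-1-yl in place of 4-methylpiperidin-1-yl gives a 4.0-fold higher number from compound 2 to compound 3 (0.60 log units; beyond the scatter). Set against the unsubstituted piperidin-1-yl, the same group gives a 1.7-fold higher number from compound 1 to compound 3 (0.23 log units; within the scatter), so the larger group with its added aromatic ring offers no gain over the plain ring, and the edge held by compound 2 is not kept. The position therefore responds to the terminal group in both steps beyond the scatter, but no information on hand bears on what lies behind this.

The compounds shown do not separate the piperazine ring from the pyridin-4-yl group, and a 4-methylpiperazin-1-yl group at the same place would compare directly with compound 2 in one change. Also open, as far as these compounds go, is how an open-chain dimethylamino terminus or a morpholine ring would compare with these rings, and whether a shorter or longer chain would alter the steps seen here.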